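The source may report more compounds than this note shows. Statements on the series, on what has been measured and on what is new or still open speak of the compounds shown alone.

Measured compounds in an ADME assay on C8166 cells (Homo sapiens) for cytotoxicity, read by MTT assay; on this read-out higher numbers stand for lower toxicity in this test and lower numbers for higher toxicity in this test:
compound 1 `Cc1cc(S(N)(=O)=O)ccc1NC(=O)COc1ccc(F)cc1Oc1ccc2ccccc2c1` gives 68600 nM
compound 2 `Cc1cc(S(N)(=O)=O)ccc1NC(=O)COc1ccc(Cl)cc1Oc1ccc2ccccc2c1` gives 119000 nM
compound 3 `Cc1cc(S(N)(=O)=O)ccc1NC(=O)COc1ccc(F)cc1Oc1ccc2cc(C#N)ccc2c1Br` gives 35300 nM

Compound 2 stands highest of the three numbers in this assay; its gap to compound 1 is within the scatter, its gap to compound 3 beyond it. Compound 4 `Cc1cc(S(N)(=O)=O)ccc1NC(=O)COc1ccc(Cl)cc1Oc1c(C)cc2ccccc2c1Cl` differs from compound 2 by 1-chloro-3-methylnaphthalen-2-yl in place of naphthalen-2-yl on an oxygen on an aromatic ring. Among the compounds with values here, no measured step changes this part of the structure: the only measured step, a 1.7-fold higher number from compound 1 to compound 2 (0.24 log units; within the scatter), concerns the halogen on the central ring and lies within the scatter. Within the data shown here, compound 1 and compound 3 differ in the naphthalenyl ring, and compound 3 shows the lower number, though no single-place step connects them. A small step downward is therefore expected, a 1.7-fold lower number from compound 2 to compound 4 (0.23 log units; within the scatter), and compound 4 is estimated at 70000 nM (range 30000 nM to 160000 nM).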

Compound 4, half-maximal cytotoxic concentration: 42600 nM
The estimate for compound 4 lay 1.6-fold (0.22 log units) above the measured number; measured number inside the range.
By their numbers in this assay, from the lowest: compounds 3, 4, 1 and 2 (each within the scatter of the next, the first and the last beyond it).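

In this assay, within the data shown here, the aryl group on the oxygen gives the first single-place step beyond the scatter (a 2.8-fold lower number from compound 2 to compound 4 (0.45 log units; beyond the scatter)), with 1-chloro-3-methylnaphthalen-2-yl in place of naphthalen-2-yl. The chloro for fluoro step (a 1.7-fold higher number from compound 1 to compound 2 (0.24 log units; within the scatter)) stayed within the scatter, so this position is the first shown where one change moves the number, here towards higher toxicity in this test. Nothing measured accounts for this step.

The compounds shown leave open whether the chlorine or the methyl group carries the step. Also open, as far as these compounds go, is how an amine or a carboxylic acid on the naphthalene would read.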